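Swapping a cyclohexyl for a small branched chain

The source may report more compounds than this note shows. Statements on the series, on what has been measured and on what is new or still open speak of the compounds shown alone.

Compound 2 `N#CN/C(=N\C1CCCCC1)Nc1cccnc1` carries a cyclohexyl group on a double-bonded nitrogen. Among the measured compounds shown here, in a functional assay on the whole organism (blood, strain Wistar-Okamoto) with Rattus norvegicus as the target, with a stated time of 5 days (on this read-out lower numbers stand for an effect already at smaller amounts and higher numbers for an effect only at larger amounts of compound), compound 2 gives 20 mg/kg, the only firm number in this set. Compound 1 `CCCCCCC/N=C(\NC#N)Nc1cccnc1`, which carries a heptyl chain at the same place, reaches only a limit of this assay: compound 1 gives > 50 mg/kg, so it sits at the limit of > 50 mg/kg in this assay, at which 1 of the 2 values shown sits, rather than at a number. Compound 3 `C=C(C)C/N=C(\NC#N)Nc1cccnc1` is the untested member; the change from compound 2 is 2-methylprop-2-en-1-yl in place of cyclohexyl on a double-bonded nitrogen. A step of a 1.8-fold higher number from compound 2 to compound 3 (0.24 log units; within the scatter) toward a larger dose is expected, beyond the usual scatter. Compound 3 is therefore estimated at 35 mg/kg, within 12 mg/kg to 100 mg/kg.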

Compound 3, minimum effective dose: 20 mg/kg
The estimate for compound 3 lay 1.8-fold (0.24 log units) above the measured number; low and high end bracket the measured number.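

With 2-methylprop-2-en-1-yl in place of cyclohexyl on a double-bonded nitrogen, this assay shows no change at the digits printed from compound 2 to compound 3 (within the scatter), so a ring at this place is not required for this dose. The heptyl chain compares differently: an at least 2.5-fold lower number from compound 1 to compound 3 (0.39 log units; beyond the scatter) comes with 1-methylethenyl in place of hexyl on a saturated chain carbon bound to a double-bonded nitrogen. Compound 1 stands at a limit, not at a firm number: the limit of > 50 mg/kg in this assay, at which 1 of the 3 values shown sits. The compounds shown leave open how a straight butyl chain or a phenyl ring would compare at this place. Such groups could help separate the effects of chain length, branching and the double bond.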